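Removing the Oxolanyl Ether: A Hydroxy Analogue of Compound 2

A few compounds are considered here, and "the series" means these few. Any claim that something is new, unique, unknown or untested is made for them only; others in the source may bear on it.

Measured compounds and their values:
compound 1 `CCOP(=O)(OCC)OCCc1cn(-c2ccc(NC(=O)Nc3ccccc3C)cc2)nn1` gives 890 nM in an assay on isolated protein for inhibition of ATP-dependent RNA helicase DDX3X (Homo sapiens), read by FRET, with stated times of 30 s and 40 min; a higher number here means a weaker inhibitor, a lower number a stronger inhibitor;
compound 2 `CCCCc1cn(-c2ccc(NC(=O)Nc3cc(OC4CCOC4)ccc3C)cc2)nn1` gives 100 nM in this assay;
compound 3 `Cc1ccccc1NC(=O)Nc1ccc(-n2cc(CCCN3CCN(C)CC3)nn2)cc1` gives 40100 nM in this assay.

Compound 2 has the lowest number of the three, and its gaps to compound 1 and to compound 3 both lie beyond the scatter, so it is the strongest inhibitor here. Among the compounds with values here, the only single-site step among the measured compounds is a 45-fold higher number from compound 1 to compound 3 (1.65 log units; beyond the scatter); that change sits on the saturated chain attached to the shared core, not on the ring where compound 2 and compound 4 differ.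

Compound 4 `CCCCc1cn(-c2ccc(NC(=O)Nc3cc(O)ccc3C)cc2)nn1` differs from compound 2 by hydrogen in place of oxolan-3-yl on an oxygen on an aromatic ring. Within the data shown here, no measured pair reports what this change does in this assay, so the expectation rests only on the fact that compound 2 is the strongest of the set and that a small loss of structure more often costs than gains. A modest rise in the number is expected, a 3.0-fold higher number from compound 2 to compound 4 (0.48 log units; beyond the scatter). Compound 4 is therefore estimated at 300 nM, with a range from 100 nM to 900 nM.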

Compound 4, half-maximal inhibitory concentration: 490 nM
Beside the measured number, compound 4's estimate is 1.6-fold (0.21 log units) below it, within the range that was stated.
By their numbers in this assay, from the lowest: compound 2; then compounds 4 and 1 (each within the scatter of the next); then compound 3.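

Within the data shown here, until now, the only step between measured compounds lay on the saturated chain, so nothing showed what the group on this oxygen contributes. In this assay, replacing oxolan-3-yl with hydrogen gives a 4.9-fold higher number from compound 2 to compound 4 (0.69 log units; beyond the scatter), which shows that the oxolanyl ether lowers the number in this series, while its removal leaves a hydroxy compound that still has a measurable value. No available evidence shows why the number changes with this swap.

The compounds shown leave open whether a group smaller than oxolan-3-yl, such as methyl, or an open chain, such as 2-methoxyethyl, on the same oxygen would give a value nearer that of compound 2. They also leave open whether this step would keep its size if the butyl chain of compound 2 were replaced by another chain.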